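The compounds below may be only part of what the source reports. "The series", "measured", "known", "first", "only" and "open" are said of these compounds alone.

Carbonate series on a shared core. Compound 1 `CC(C)CCOC(=O)OCC(CO)CCn1cnc2cnc(N)nc21` gives 5600 ug/mL in a physicochemical assay for solubility, read by spectrophotometry, at 20 degrees C; on this read-out lower numbers stand for lower solubility and higher numbers for higher solubility. Compound 2 `CC(C)OC(=O)OCC(CO)CCn1cnc2cnc(N)nc21` gives 139000 ug/mL in this assay, and compound 3 `COC(=O)OCC(CO)CCn1cnc2cnc(N)nc21` gives 14100 ug/mL, so compound 1 holds the lowest of the three numbers. Compound 4 `CCOC(=O)OCC(CO)CCn1cnc2cnc(N)nc21` is reached from compound 1 by hydrogen in place of isopropyl on a saturated chain carbon, two bonds along the chain from an oxygen next to a carbonyl group. Among the compounds with values here, two measured steps bear on this: a 25-fold higher number from compound 1 to compound 2 (1.39 log units; beyond the scatter) and a 2.5-fold higher number from compound 1 to compound 3 (0.40 log units; beyond the scatter). Both trim the same ester-side group and both raise the number; the ethyl of compound 4 sits in length among isopentyl, isopropyl and methyl. A rise beyond the scatter is therefore expected for compound 4, of roughly a 7.1-fold higher number from compound 1 to compound 4 (0.85 log units; beyond the scatter). Compound 4 is estimated at 40000 ug/mL, with a range of 12000 ug/mL to 130000 ug/mL.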

Compound 4, solubility: 20000 ug/mL
For compound 4 the middle estimate is 2.0-fold (0.30 log units) above the measured one; the range from low to high includes it.
By their numbers in this assay, from the lowest: compound 1; then compounds 3 and 4 (each within the scatter of the next); then compound 2.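

Going from isopentyl to ethyl gives a 3.6-fold higher number from compound 1 to compound 4 (0.55 log units; beyond the scatter) in this assay, yet ethyl and methyl are not separated, with a 1.4-fold higher number from compound 3 to compound 4 (0.15 log units; within the scatter). Isopropyl stands apart from ethyl, with a 7.0-fold lower number from compound 2 to compound 4 (0.84 log units; beyond the scatter), so compound 2 goes against any ordering by chain size across these four compounds, while branched compound 1 holds the lowest number. Nothing available explains why isopropyl stands apart.

As far as these compounds go, whether that high value is particular to isopropyl remains open, with cyclopropyl and tert-butyl as untested neighbours. Also open, from the compounds shown here alone, is how an amine or a carboxylic acid at the chain end would read.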